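This account rests on a few compounds, and the source may have more. Where it says the series, first, only, none or still open, it means among the compounds named here.

In an ADME assay on microsomes from liver (Homo sapiens) for pharmacokinetics, read by LC-MS, with a stated time of 60 min, tested at 1 uM (a higher number here means faster removal of the compound, a lower number slower removal), compound 1 (`O=C(NCc1ccc(S(=O)(=O)c2ccccc2)cc1)N1Cc2ccncc2C1`) gives 7.5 mL/min/kg and compound 2 (`O=C(NCc1ccc(S(=O)(=O)c2cccc(C(F)(F)F)c2)cc1)N1Cc2ccncc2C1`) gives 14 mL/min/kg on the same scale. The two numbers cannot be told apart, so compound 2 stands level with compound 1 within the scatter. Compound 3 (`O=C(NCc1ccc(S(=O)(=O)c2cncc(C(F)(F)F)c2)cc1)N1Cc2ccncc2C1`) differs from compound 2 by one change (5-(trifluoromethyl)pyridin-3-yl in place of 3-(trifluoromethyl)phenyl on a sulfonyl sulfur) in which 5-(trifluoromethyl)pyridin-3-yl takes the place of 3-(trifluoromethyl)phenyl on a sulfonyl sulfur. Among the measured compounds shown here, no measured pair shows this exchange. For the measured compounds named here, the only guide to size is a 1.9-fold higher number from compound 1 to compound 2 (0.27 log units; within the scatter) for trifluoromethyl in place of hydrogen on an aromatic carbon, so a step beyond the scatter is not expected. The estimated step is a 1.4-fold lower number from compound 2 to compound 3 (0.15 log units; within the scatter) and it is expected to lean slightly toward slower removal while staying inside the scatter. For compound 3 the estimate is 10 mL/min/kg with an expected range from 5 mL/min/kg to 20 mL/min/kg for this measurement.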

Compound 3, clearance: 13 mL/min/kg
Estimate against measurement, compound 3: 1.3-fold (0.11 log units) below; the range from low to high includes it.
By their numbers in this assay, from the lowest: compounds 1, 3 and 2 (each within the scatter of the next).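

In this assay, 5-(trifluoromethyl)pyridin-3-yl in place of 3-(trifluoromethyl)phenyl on a sulfonyl sulfur gives a 1.1-fold lower number from compound 2 to compound 3 (0.03 log units; within the scatter), so swapping one ring carbon for a nitrogen does not separate these two compounds. Set against the plain phenyl, the same pyridine group gives a 1.7-fold higher number from compound 1 to compound 3 (0.24 log units; within the scatter), which means that all three groups seen at this place stay level within the scatter. Nothing measured here explains why the numbers stay so close.

The compounds shown leave open whether a plain pyridin-3-yl without trifluoromethyl would behave the same way, since the nitrogen is seen only together with that group. Also open, on these data alone, is whether an amine or a carboxylic acid on this ring would move clearance beyond the scatter, and what changes to the shared core would do.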